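Methylation of a phenol hydroxy in the hydrazone series

The source may hold more compounds than are shown below. What is called first, only, known or untested is meant among the compounds shown, and "the series" means these compounds.

Measured compounds and their values in a physicochemical assay on cells (Homo sapiens), with a stated time of 18 h, tested at 10 uM; a lower number here means a stronger effect, a higher number a weaker effect of the compound at the concentration tested:
compound 1 `COc1cc(/C=N/Nc2nc3ccccc3s2)cc(OC)c1O` gives 3%
compound 2 `COc1cc(/C=N/Nc2nc3ccccc3s2)cc(OC)c1OC` gives 14%
compound 3 `Oc1ccc(/C=N/Nc2nc3ccccc3s2)cc1O` gives 7%

Compound 3 sits second highest of the three numbers in this assay. Its nearest neighbour is compound 1 and its furthest compound 2, and both gaps lie within the scatter, so no order among the three can be claimed.

Compound 4 `COc1cc(/C=N/Nc2nc3ccccc3s2)ccc1O` has not yet been measured. It differs from compound 3 by methyl in place of hydrogen on an oxygen on an aromatic ring.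

For the measured compounds named here, the one measured step that bears on this change is a number 11 percentage points higher from compound 1 to compound 2 (beyond the scatter). That step is the same kind of change on the same kind of oxygen and shifted the number upward by a modest margin. Going by the values given here, a shift of similar size and direction is therefore expected here, though only one prior example supports it.

The step from compound 3 to compound 4 is expected to be a number 8 percentage points higher from compound 3 to compound 4 (within the scatter). Compound 4 is thus estimated at 15%, with a range from 4% to 28%.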

Compound 4, a percentage reported as activity, at one concentration (the size of the read-out at that concentration, not a potency): 7%
For compound 4 the middle estimate is 8 percentage points above the measured one; measured number inside the range.
By their numbers in this assay, from the lowest: compounds 1, 3, 4 and 2 (each within the scatter of the next, the first and the last beyond it).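

In this assay, methyl in place of hydrogen on an oxygen on an aromatic ring gives no change at the digits printed from compound 3 to compound 4 (within the scatter), whereas the same change gave a number 11 percentage points higher from compound 1 to compound 2 (beyond the scatter), so hydroxy to methoxy does not carry one fixed outcome across these two compounds. Hydrogen in place of methoxy on an aromatic carbon gives a number 4 percentage points higher from compound 1 to compound 4 (within the scatter), so with the hydroxy kept, that methoxy shows no readable contribution to the read-out. No measured evidence explains why the methylation step is beyond the scatter in one compound and within it in the other.

As far as these compounds go, it remains open whether an ethyl group or a longer chain on this oxygen would also stay within the scatter of compound 3. From the compounds shown here alone, the effect of an amine or a carboxylic acid in place of the hydroxy also remains open.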